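Swapping a hydroxy for a nitro on the anilino ring

The compounds below may be only part of what the source reports. "The series", "measured", "known", "first", "only" and "open" are said of these compounds alone.

Measured compounds:
- compound 1, `Cn1nc(-c2ccnc(Nc3cccc(O)c3)n2)c2ccccc21`: 28200 nM
- compound 2, `Cn1nc(-c2ccnc(Nc3ccc(Cl)cc3)n2)c2ccccc21`: 7830 nM

In a functional assay on MCF7 cells (Homo sapiens) for antiproliferative activity, read by MTT assay, with a stated time of 72 h (a lower number here means a stronger inhibitor of growth, a higher number a weaker inhibitor of growth), compound 1 gives the highest of the two numbers; the nearest is compound 2, reached by a 3.6-fold lower number from compound 1 to compound 2 (0.56 log units; beyond the scatter), where a 4-chlorophenyl replaces the 3-hydroxyphenyl on a nitrogen on an aromatic ring.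

Compound 3, `Cn1nc(-c2ccnc(Nc3cccc([N+](=O)[O-])c3)n2)c2ccccc21`, is not yet measured. It differs from compound 1 by nitro in place of hydroxy on an aromatic carbon, meta to a large group. Among the measured compounds shown here, the only measured step changes both group and position, so it bears loosely here. A change of similar or smaller size is expected, a 2.0-fold lower number from compound 1 to compound 3 (0.30 log units; within the scatter). Compound 3 is therefore estimated at 14000 nM, within 4000 nM to 50000 nM.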

Compound 3, concentration for 50% growth inhibition: 580 nM
Beside the measured number, compound 3's estimate is 24-fold (1.38 log units) above it, outside the stated range (below it).
By their numbers in this assay, from the lowest: compound 3; then compound 2; then compound 1.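

In this assay, nitro in place of hydroxy on the same aromatic carbon gives a 49-fold lower number from compound 1 to compound 3 (1.69 log units; beyond the scatter) and is a large change. Unlike the earlier step, this one changes the group alone while its place on the ring stays the same, so the difference belongs to the swap itself. Nothing available here accounts for the size of this step. From the compounds shown here alone, whether an amine, a methoxy or a nitrile at this same place would match nitro remains open. So does whether nitro would give a similar result elsewhere on the ring.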